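The compounds below may be only part of what the source reports. "The series", "measured", "known", "first", "only" and "open" are said of these compounds alone.

Three compounds have been measured in a functional assay on Raji cells (Homo sapiens) for antiproliferative activity, read by CCK-8 assay, with a stated time of 72 h, tested at 40 uM; on this read-out higher numbers stand for more inhibition at the one concentration tested (going by the name of the read-out) and lower numbers for less inhibition:

compound 1 `CCOC(=O)c1sc(-c2cccc(NC(=O)c3ccc(F)cc3)c2)nc1Nc1ccc(N2CCN(C)CC2)cc1` gives 16.8%
compound 2 `CCOC(=O)c1sc(-c2cccc(NC(=O)c3ccc(Cl)cc3)c2)nc1Nc1ccc(N2CCN(C)CC2)cc1` gives 24.3%
compound 3 `CCOC(=O)c1sc(-c2cccc(NC(=O)c3ccc(C#N)cc3)c2)nc1Nc1ccc(N2CCN(C)CC2)cc1` gives 79.1%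

Compound 3 stands highest of the three in this assay, beyond the scatter from both others: the step of a number 54.8 percentage points higher from compound 2 to compound 3 (beyond the scatter) and the step of a number 62.3 percentage points higher from compound 1 to compound 3 (beyond the scatter) are both large, whereas the step of a number 7.5 percentage points higher from compound 1 to compound 2 (within the scatter) stays within the scatter. Compound 4 `CCOC(=O)c1sc(-c2cccc(NC(=O)[C@H]3CC[C@H](C)CC3)c2)nc1Nc1ccc(N2CCN(C)CC2)cc1` differs from compound 3 by 4-methylcyclohexyl in place of 4-cyanophenyl on a carbonyl carbon. Among the measured compounds shown here, no measured step exchanges an aromatic ring for a non-aromatic one, so that part of the change is without precedent here. What the measured steps do show is that the large rises from compound 1 and compound 2 to compound 3 each came with cyano entering; compound 4 loses that cyano group again, and what enters carries no hydrogen-bond acceptor. Because of a number 62.3 percentage points higher from compound 1 to compound 3 (beyond the scatter) and a number 54.8 percentage points higher from compound 2 to compound 3 (beyond the scatter), a large fall in this assay is expected from compound 3 to compound 4, a number 54.1 percentage points lower from compound 3 to compound 4 (beyond the scatter), back towards the region of compound 1 and compound 2. Compound 4 is therefore estimated at 25%, in the range 8% to 55%.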

Compound 4, a percentage reported as inhibition, at one concentration (the size of the read-out at that concentration, not a potency): 26.1%
Compound 4: middle estimate off by 1.1 percentage points, on the low side; measured number inside the range.
By their numbers in this assay, from the lowest: compounds 1, 2 and 4 (each within the scatter of the next); then compound 3.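

In this assay the exchange of 4-cyanophenyl for 4-methylcyclohexyl on the carbonyl carbon gives a number 53 percentage points lower from compound 3 to compound 4 (beyond the scatter) and shows that a non-aromatic ring without a nitrile does not keep the high number of compound 3. Set against the halogen-bearing phenyl amides, the same kind of ring exchange gives a number 1.8 percentage points higher from compound 2 to compound 4 (within the scatter) and a number 9.3 percentage points higher from compound 1 to compound 4 (within the scatter), so among these compounds, aromatic or non-aromatic ring alone makes no readable difference and only compound 3 stands apart. No measurement here explains why the nitrile-bearing compound differs from the other three.

From the compounds shown here alone, whether the high number needs the nitrile on an aromatic ring, or would also appear with a nitrile on the cyclohexyl ring, remains open. Going by these compounds, it is equally open whether a nitro group or a carboxylic acid in place of the nitrile would behave like compound 3 or like the others.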